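Methoxy in Place of Cyclopropyloxy on a Shared Core

A few compounds are considered here, and "the series" means these few. Any claim that something is new, unique, unknown or untested is made for them only; others in the source may bear on it.

For the measured compounds named here, compound 1 `CC(Oc1ccccc1OC1CC1)C1=NCCN1` gives 0.7 in an assay on CHO cells with Alpha-2C adrenergic receptor (Homo sapiens) as the target (a lower number here means a smaller maximal response, a higher number a larger maximal response), the lowest of the two numbers measured so far. Compound 2 `C=C(C)c1ccccc1OC(C)C1=NCCN1` gives 0.71 in this assay, and the step a number 0.010 higher from compound 1 to compound 2 (within the scatter) lies within the scatter. Compound 3 `COc1ccccc1OC(C)C1=NCCN1` differs from compound 1 by methyl in place of cyclopropyl on an oxygen on an aromatic ring. Going by the values given here, only that one measured step bears on this change, since it too swaps the group carried on an aromatic carbon of the shared core, and it showed no movement beyond the scatter. The expected step of no change at the digits printed from compound 1 to compound 3 (within the scatter) is therefore estimated to stay within the scatter. Compound 3 is expected to give about 0.7 in this assay, within the range 0.55 to 0.85.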

Compound 3, intrinsic activity: the largest response reached, as a fraction of the reference agonist's: 0.6
For compound 3 the middle estimate is 0.10 above the measured one; the range from low to high includes it.
By their numbers in this assay, from the lowest: compounds 3, 1 and 2 (each within the scatter of the next, the first and the last beyond it).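

In this assay, methoxy can replace cyclopropyloxy with a number 0.10 lower from compound 1 to compound 3 (within the scatter), so shortening the group on this oxygen to methyl leaves the maximal response within the usual spread of repeats. Methoxy in place of 1-methylethenyl on an aromatic carbon gives a number 0.11 lower from compound 2 to compound 3 (beyond the scatter), the first step in this set to pass beyond the scatter, though only modestly. Nothing available explains either step.

The compounds shown leave open how an amine or a carboxylic acid on this aromatic carbon would compare. They also leave open what a longer chain on the oxygen would do to the maximal response.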